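The source may report more compounds than this note shows. Statements on the series, on what has been measured and on what is new or still open speak of the compounds shown alone.

In a functional assay on PC-3 cells (Homo sapiens) for inhibition, read by MTT assay, with a stated time of 48 h (a higher number here means a weaker inhibitor, a lower number a stronger inhibitor), compound 1 `COc1cc(-c2nnc(SCC(=O)c3ccccc3)n2-c2ccc(N(C)C)cc2)cc(OC)c1OC` gives 38600 nM and compound 2 `COc1ccc(NC(=O)CSc2nnc(-c3cc(OC)c(OC)c(OC)c3)n2-c2ccc(N(C)C)cc2)cc1` gives 56100 nM. Within the data shown here, these two numbers lie within the scatter of each other, so compound 2 stands level with its only measured neighbour. Compound 3 `COc1cc(-c2nnc(SCC(=O)Nc3ccc(Cl)cc3)n2-c2ccc(N(C)C)cc2)cc(OC)c1OC` differs from compound 2 by one substituent, with chloro in place of methoxy on an aromatic carbon, para to a large group: chloro in place of methoxy on an aromatic carbon. Among the measured compounds shown here, no measured pair makes this exact swap. For the measured compounds named here, the only measured step that bears on it is a 1.5-fold higher number from compound 1 to compound 2 (0.16 log units; within the scatter), which also altered this aromatic ring and stayed within the scatter. On that slim evidence, no clear shift in either direction is expected, and the expected step is a 1.2-fold lower number from compound 2 to compound 3 (0.10 log units; within the scatter). For compound 3 the estimated value is 45000 nM, with an expected range from 18000 nM to 100000 nM.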

Compound 3, half-maximal inhibitory concentration: > 60000 nM
Compound 3 was reported as a limit; the forecaster's own chance of this, stated with the estimate: 10%; middle value at least 1.3-fold (0.12 log units) from the limit.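

Compound 3 is reported only as a limit, not as a number: the limit of > 60000 nM in this assay, at which 1 of the 3 values shown sits.

Chloro in place of methoxy on this aromatic carbon, para to a large group, gives an at least 1.0-fold higher number from compound 2 to compound 3 (0.02 log units; that floor lies within the scatter), so this swap does not turn compound 2 into a clearly stronger inhibitor, while the true size of the change remains unknown. Replacing phenyl on the carbonyl carbon with (4-chlorophenyl)amino gives an at least 1.5-fold higher number from compound 1 to compound 3 (0.19 log units; that floor lies within the scatter), so the amide bearing chloro is likewise not shown to differ clearly from the ketone of compound 1, though a larger gap cannot be excluded.

From the compounds shown here alone, the real value of compound 3 stays open, and with it the order of the three compounds. Also open, going by these compounds, is how an amine, a hydroxyl or a methyl group on this same aromatic carbon would read.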